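A few compounds are considered here, and "the series" means these few. Any claim that something is new, unique, unknown or untested is made for them only; others in the source may bear on it.

Compound 1 `Nc1sc(-c2ccc(Cl)cc2)c(-c2ccc(Cl)cc2)c1C(=O)NC1CCCCC1` gives 7300 nM in a functional assay on PC-3 cells (Homo sapiens) for inhibition, read by sulforhodamine B assay, with a stated time of 72 h; on this read-out higher numbers stand for weaker inhibition and lower numbers for stronger inhibition.
Compound 2 `Nc1sc(-c2ccc(Cl)cc2)c(-c2ccc(Cl)cc2)c1C(=O)Nc1ccccc1` reaches only the limit of this assay, > 50000 nM.
Compound 3 `CN1CCN(C(=O)c2c(N)sc(-c3ccc(Cl)cc3)c2-c2ccc(Cl)cc2)CC1` gives 13100 nM in this assay.

Among these values compound 1 holds the lowest of the two plain numbers, and compound 3 sits nearest to it; the two are within the usual scatter of each other, so neither can be called the stronger. Compound 2 is known only as a limit.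

Compound 4 `Nc1sc(-c2ccc(Cl)cc2)c(-c2ccc(Cl)cc2)c1C(=O)N1CCCC1` differs from compound 1 in one place: pyrrolidin-1-yl in place of cyclohexylamino on a carbonyl carbon. Among the measured compounds shown here, two measured steps bear on this. Replacing the cyclohexyl with a phenyl on the amide-type nitrogen gave an at least 6.8-fold higher number from compound 1 to compound 2 (0.83 log units; beyond the scatter). Replacing the whole cyclohexylamino with 4-methylpiperazin-1-yl on the carbonyl carbon gave a 1.8-fold higher number from compound 1 to compound 3 (0.25 log units; within the scatter). The change to compound 4 resembles the second of these, as a ring that sits on the carbonyl carbon through its own nitrogen, so only a small step is expected here. Compound 4 is expected to show a 1.4-fold higher number from compound 1 to compound 4 (0.14 log units; within the scatter). The estimate for compound 4 is 10000 nM, with a plausible range from 4000 nM to 30000 nM.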

Compound 4, half-maximal inhibitory concentration: 6220 nM
Compound 4: middle estimate off by 1.6-fold (0.21 log units), on the high side; low and high end bracket the measured number.
By their numbers in this assay, from the lowest: compounds 4, 1 and 3 (each within the scatter of the next, the first and the last beyond it). At a limit, above all of these: compound 2.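

Replacing cyclohexylamino with pyrrolidin-1-yl on the carbonyl carbon removes the amide hydrogen and changes the ring, yet it gives a 1.2-fold lower number from compound 1 to compound 4 (0.07 log units; within the scatter) in this assay, so this change does not separate compound 4 from compound 1. The choice of ring joined through its own nitrogen does register, if only modestly, with a 2.1-fold lower number from compound 3 to compound 4 (0.32 log units; beyond the scatter), whereas compound 3 could not be told apart from compound 1 on its own. The anilino group remains the one clear outlier at this position, with an at least 8.0-fold lower number from compound 2 to compound 4 (0.90 log units; beyond the scatter), and that step is only a bound, as the value of compound 2 is a limit and not a number: the limit of > 50000 nM in this assay, at which 1 of the 4 values shown sits.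

As far as these compounds go, how far this position tolerates change remains open, for example with piperidin-1-yl, morpholin-4-yl or an open-chain group such as diethylamino, any of which would show whether ring size or the ring itself matters. The two chlorophenyl groups and the free amino group stay the same throughout, so what a fluorine or methoxy group on those rings would do is also unknown.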